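The source may report more compounds than this note shows. Statements on the series, on what has been measured and on what is new or still open speak of the compounds shown alone.

Compound 1 `O=C1NC(=O)C(Cc2ccc(OCC3CCCCC3)cc2)S1` – 26000 nM
Compound 2 `CCC(C)(C)Oc1ccc(/C=C2\SC(=O)NC2=O)cc1` – 15000 nM

In a functional assay on PC-12 cells (Rattus norvegicus) for inhibition, read by sulforhodamine B assay (a lower number here means a stronger inhibitor, a higher number a weaker inhibitor), compound 1 gives 26000 nM, and compound 2 gives 15000 nM, within the scatter of it, so the two cannot be ranked. Compound 3 `CCCOc1ccc(CC2SC(=O)NC2=O)cc1` changes compound 1 in one place: ethyl in place of cyclohexyl on a saturated chain carbon bound to an oxygen on an aromatic ring. Within the data shown here, no measured step covers this change. A small move in this assay toward a higher number is expected, possibly none beyond the scatter. The expected step is a 1.3-fold higher number from compound 1 to compound 3 (0.13 log units; within the scatter). For compound 3 the estimate is 35000 nM, with an expected range of 12000 nM to 100000 nM.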

Compound 3, half-maximal inhibitory concentration: 45000 nM
The estimate for compound 3 lay 1.3-fold (0.11 log units) below the measured number; measured number inside the range.
By their numbers in this assay, from the lowest: compounds 2, 1 and 3 (each within the scatter of the next, the first and the last beyond it).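

In this assay, ethyl in place of cyclohexyl on a saturated chain carbon bound to an oxygen on an aromatic ring gives a 1.7-fold higher number from compound 1 to compound 3 (0.24 log units; within the scatter), so compound 1 and compound 3 cannot be ranked. For this pair, removing the six-membered ring at this position produces no step beyond the scatter. Nothing available explains the size of this step.

From the compounds shown here alone, whether a longer chain, an amine or a carboxylic acid at this position would produce a clear step remains open. Compound 2 differs from compound 1 in more than one place, so the effect of its tert-pentyl-type ether group cannot be separated from other changes.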